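Amide for amine at the ring enone carbon: compound 4

The source may hold more compounds than are shown below. What is called first, only, known or untested is meant among the compounds shown, and "the series" means these compounds.

The series in a functional assay on MCF7 cells (Homo sapiens) for antiproliferative activity, read by MTT assay, with a stated time of 48 h (on this read-out lower numbers stand for stronger inhibition and higher numbers for weaker inhibition), so far holds compound 1 `CO[C@]1(C)/C=C/C(=O)/C(CO)=C\C[C@](C)(CCC=C(C)C)/C=C/[C@H]1OC(=O)C=C(C)C`, compound 2 `CC(C)=CCC[C@]1(C)/C=C/[C@@H](OC(=O)C=C(C)C)[C@](C)(O)/C=C/C(=O)/C(CN(C(C)C)C(C)C)=C\C1` and compound 3 `CC(C)=CCC[C@]1(C)/C=C/[C@@H](OC(=O)C=C(C)C)[C@](C)(O)CCC(=O)/C(CO)=C\C1`. Compound 2 gives 780 nM, the lowest of the two numbers, with compound 1 at 14300 nM as the nearest value and beyond the scatter. For compound 3 this assay reports only a limit, > 40000 nM, as noted in the limit of > 40000 nM in this assay, at which 1 of the 3 values shown sits. Compound 4 `CC(C)=CCC[C@]1(C)/C=C/[C@@H](OC(=O)C=C(C)C)[C@](C)(O)/C=C/C(=O)/C(C(=O)N(C)C)=C\C1` is not yet measured; it differs from compound 2 by dimethylcarbamoyl in place of (diisopropylamino)methyl on a double-bonded ring carbon. For the measured compounds named here, with no one-place step measured, the expectation rests on compound 2 alone, and a step toward weaker inhibition is expected, a 6.4-fold higher number from compound 2 to compound 4 (0.81 log units; beyond the scatter). Compound 4 is accordingly estimated at 5000 nM, within 1500 nM to 20000 nM.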

Compound 4, half-maximal inhibitory concentration: 3670 nM
Compound 4: middle estimate off by 1.4-fold (0.13 log units), on the high side, and the stated range covers the measured number.
By their numbers in this assay, from the lowest: compound 2; then compound 4; then compound 1. At a limit, above all of these: compound 3.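

In this assay, dimethylcarbamoyl in place of (diisopropylamino)methyl on this double-bonded ring carbon gives a 4.7-fold higher number from compound 2 to compound 4 (0.67 log units; beyond the scatter). The read-out therefore responds to the group at this place, yet the amide compound 4 still gives a measured number, 3670 nM. Nothing measured here accounts for the step.

The step changes the carbonyl and the groups on nitrogen together, so the compounds shown leave open which of the two carries it. A (dimethylamino)methyl group on this carbon would separate them.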